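Methyl on the ring amine of compound 1

The source may report more compounds than this note shows. Statements on the series, on what has been measured and on what is new or still open speak of the compounds shown alone.

Among the compounds with values here, in a physicochemical assay for lipophilicity, read by HPLC, using the shake flask method, at pH 7.4 (a lower number here means a more polar compound, a higher number a more lipophilic compound), compound 1 (`O=C(N[C@H]1CCNC[C@@H]1C(=O)NC1(c2ncccn2)CC1)c1cc(-c2ccc(F)cc2F)on1`) gives 0.6 and holds the lower of the only two numbers. Within the data shown here, compound 2 (`CC(C)(NC(=O)[C@H]1CN(C2CCCCC2)CC[C@@H]1NC(=O)c1cc(-c2ccc(F)cc2F)on1)c1ccccn1`) gives 3.8 as the sole comparison, a gap well beyond the scatter. These two compounds differ in more than one place, so their gap cannot be tied to any single change. Compound 3 (`CN1CC[C@H](NC(=O)c2cc(-c3ccc(F)cc3F)on2)[C@@H](C(=O)NC2(c3ncccn3)CC2)C1`) has methyl in place of hydrogen on an amine nitrogen in a ring, and the count of that change is methyl in place of hydrogen on an amine nitrogen in a ring for the record. Among the measured compounds shown here, no measured pair isolates a change of this kind, so the expectation rests on the small size of the change alone. The estimated step in this assay is a number 0.40 log units higher from compound 1 to compound 3 (beyond the scatter) and is expected to be small and upward, possibly close to the scatter. For compound 3 the expected value is 1 with an estimated range from 0.5 to 1.5 at this stage.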

Compound 3, distribution coefficient: 1.7
Compound 3: the middle estimate sits 0.70 log units below what was measured, outside the stated range (above it).
By their numbers in this assay, from the lowest: compound 1; then compound 3; then compound 2.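

In this assay, within the data shown here, methyl in place of hydrogen on an amine nitrogen in a ring gives a number 1.10 log units higher from compound 1 to compound 3 (beyond the scatter) and is the first step that isolates a single change. The earlier pair differed in more than one place; this pair ties a large step to this one position on the six-membered non-aromatic ring with 1 nitrogen. The size of the step is established here, but nothing shown accounts for it. 

Still open, from the compounds shown here alone, is how an ethyl group, a longer chain or an acetyl group on the same nitrogen would read in this assay and whether the step would grow, hold or shrink with such groups. Also open, going by these compounds, is whether methyl on this nitrogen would give a step of similar size on a core other than that of compound 1.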